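Replacing a fused diamine with an aminocyclohexylamino group

The compounds below may be only part of what the source reports. "The series", "measured", "known", "first", "only" and "open" are said of these compounds alone.

Of the compounds shown here, two have been measured in an ADME assay on microsomes from liver (Mus musculus) for metabolic stability, using NADPH, with a stated time of 10 min; on this read-out higher numbers stand for a more stable compound and lower numbers for a less stable compound. Compound 1, `CN1CCN(Nc2cccc3c2C[C@@H](CN(C)[C@H]2CCCc4cccnc42)NC3)CC1`, gives 85.8%. Compound 2, `CN1CC[C@H]2CN(c3cccc4c3C[C@H](CN(C)[C@H]3CCCc5cccnc53)NC4)C[C@H]21`, gives 24%, the lower of the two numbers and a gap from compound 1 that is beyond the usual scatter. Compound 3, `CN(C[C@H]1Cc2c(cccc2N[C@H]2CC[C@H](N)CC2)CN1)[C@H]1CCCc2cccnc21`, has not been measured yet. It differs from compound 2 in one place: a group of 8 heavy atoms (6 carbon, 2 nitrogen; one six-membered non-aromatic ring of carbon only) in place of a group of 9 heavy atoms (7 carbon, 2 nitrogen; 2 five-membered non-aromatic rings with 1 hetero atom each), on an aromatic carbon. Within the data shown here, with no step of this kind among the measured pair, the size of the change is uncertain. Compound 3 is expected to sit between the two measured numbers, at an estimated 55%, within a range from 25% to 85%. That estimate means a step of a number 31 percentage points higher from compound 2 to compound 3 (beyond the scatter), expected to be upward and beyond the scatter.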

Compound 3, percent of the compound remaining: 100%
The estimate for compound 3 lay 45 percentage points below the measured number; the measured number lies above the stated range.
By their numbers in this assay, from the lowest: compound 2; then compound 1; then compound 3.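

On this aromatic carbon, putting (4-aminocyclohexyl)amino in place of the group with two five-membered non-aromatic rings gives a number 76 percentage points higher from compound 2 to compound 3 (beyond the scatter) in this assay. Among these compounds, this is the first step read at this position, and it shows that a change here alone can move the read-out by a large amount. No measurement available explains why the number rises.

As far as these compounds go, what remains open is which part of the new group goes with the rise. A plain cyclohexylamino group or a 4-hydroxycyclohexylamino group at the same place would help separate the ring from its amine.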